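Three sulfonate esters at the assay ceiling, and a bromine removed

This account rests on a few compounds, and the source may have more. Where it says the series, first, only, none or still open, it means among the compounds named here.

Compound 1, `O=C(O)CCCCCCC(=O)Nc1ccc(C2=C(c3ccc(O)cc3)C3CC(S(=O)(=O)Oc4ccc(C(F)(F)F)cc4)C2O3)cc1`: in an ADME assay on Vero cells (Chlorocebus sabaeus) for inhibition, read by MTT assay, with a stated time of 72 h (a higher number here means a weaker inhibitor, a lower number a stronger inhibitor), compound 1 gives > 100000 nM, a limit of the assay.
Compound 2, `COc1ccccc1OS(=O)(=O)C1CC2OC1C(c1ccc(NC(=O)CCCCCCC(=O)NO)cc1)=C2c1ccc(O)cc1`: in this assay compound 2 gives > 100000 nM, a limit of the assay.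
Compound 3, `O=C(CCCCCCC(=O)Nc1ccc(C2=C(c3ccc(O)cc3)C3CC(S(=O)(=O)Oc4ccc(Br)cc4)C2O3)cc1)NO`: in this assay compound 3 gives > 100000 nM, a limit of the assay.

Compound 3 stands where every measured compound stands: at the limit, with no number of its own. Within the data shown here, the one measured step that runs into compound 3, a step that the two limits leave unreadable from compound 2 to compound 3, cannot be read for the same reason, and the only evidence on the measured values is the limit of > 100000 nM in this assay, at which 3 of the 3 values shown sit.

The step from compound 3 to compound 4 is small in structure: hydrogen in place of bromo on an aromatic carbon. Compound 4 is `O=C(CCCCCCC(=O)Nc1ccc(C2=C(c3ccc(O)cc3)C3CC(S(=O)(=O)Oc4ccccc4)C2O3)cc1)NO`. Among the measured compounds shown here, no measured step bears on this change, and the one step that reaches compound 3 is unreadable, so nothing in the data points to a direction. Because the limit of > 100000 nM in this assay, at which 3 of the 3 values shown sit, shows every compound of this series at the limit, compound 4 is expected to stay there as well, and the expected step that the limit leaves unreadable from compound 3 to compound 4 is estimated as none beyond the scatter. In this assay compound 4 is estimated at 150000 nM, within a range from 50000 nM to 500000 nM, most likely reported again only as a limit.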

Compound 4, half-maximal inhibitory concentration: > 100000 nM
Compound 4: a limit, no number (the forecaster's own chance of this, stated with the estimate: 85%); the middle value is on the limit's open side.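

In this assay compound 4 gives > 100000 nM, a limit of the assay. Among these compounds, neither the step to compound 4 from compound 3 nor the one from compound 2 can be read. The compounds shown leave open whether any change in this series moves the value at all: the limit of > 100000 nM in this assay, at which 4 of the 4 values shown sit.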